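The source may report more compounds than this note shows. Statements on the series, on what has been measured and on what is new or still open speak of the compounds shown alone.

Compound 1 `C[C@@H](c1c[nH]c2ncccc12)c1nnc2ccc(-c3cnn(C)c3)nn12`: 150000 nM
Compound 2 `Fc1ccc(-c2ccc3nnc(Cc4ccc5ncccc5c4)n3n2)cc1F`: 11500 nM

In a physicochemical assay for solubility, measured as kinetic solubility, at pH 6.5 (a lower number here means a less soluble compound, a higher number a more soluble compound), compound 2 holds the lower of the two numbers at 11500 nM. Its nearest neighbour, compound 1, reads 150000 nM, a gap beyond the usual scatter. The two compounds differ in more than one place, so this gap cannot be tied to any single change.

Compound 3 `Nc1ccc2nnc(Cc3ccc4ncccc4c3)n2n1` departs from compound 2 at one place: amino in place of 3,4-difluorophenyl on an aromatic carbon. For the measured compounds named here, no measured pair shows this change on its own, so the expectation rests on the structural change and on the two readings alone.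

A rise beyond the scatter is expected in this assay, taking compound 3 towards the reading of compound 1 at 150000 nM. The expected step is a 7.8-fold higher number from compound 2 to compound 3 (0.89 log units; beyond the scatter). For compound 3 the estimated value is 90000 nM, with an expected range of 30000 nM to 200000 nM.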

Compound 3, solubility: 453000 nM
Beside the measured number, compound 3's estimate is 5.0-fold (0.70 log units) below it; measured number above the stated range.
By their numbers in this assay, from the lowest: compound 2; then compound 1; then compound 3.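

In this assay, the change from 3,4-difluorophenyl to amino on an aromatic carbon of the six-membered aromatic ring with 2 nitrogen gives a 39-fold higher number from compound 2 to compound 3 (1.60 log units; beyond the scatter). For the compounds shown here, this is the first step that can be tied to one place, since the earlier pair differed in more than one, and it shows that the reading responds strongly to the group at this position while the rest of the molecule stays the same. The change swaps 8 heavy atoms, including one six-membered aromatic ring of carbon only, for 1 nitrogen with 1 hydrogen-bond donor and 1 hydrogen-bond acceptor, and no measurement at hand accounts for the size of the step.

The compounds shown leave open whether the step follows from the loss of the 3,4-difluorophenyl or from the arrival of the amino, as the single change holds both; a plain phenyl, a methoxy or a dimethylamino at this position would help to separate the two. They also leave open whether the same change would give a step of similar size on the core of compound 1.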